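Chloro for tert-butyl on the Benzamide Ring

The compounds below may be only part of what the source reports. "The series", "measured", "known", "first", "only" and "open" are said of these compounds alone.

The series shares one core, an aminothiazole carrying a benzamide-bearing aryl group and a methylpiperazinyl aniline. Compound 1 `CCOC(=O)c1sc(-c2cccc(NC(=O)c3ccc(Cl)cc3)c2)nc1Nc1ccc(N2CCN(C)CC2)cc1` is the ethyl ester; in a functional assay on Raji cells (Homo sapiens) for antiproliferative activity, read by CCK-8 assay, with a stated time of 72 h (a lower number here means a stronger inhibitor, a higher number a weaker inhibitor), compound 1 gives "not determined" (no result reported), so no result for it was reported. Compound 2 `CN1CCN(c2ccc(Nc3nc(-c4cccc(NC(=O)c5ccc(Cl)cc5)c4)sc3C(=O)O)cc2)CC1` is the free acid, and in this assay compound 2 gives 7020 nM. Compound 3 `CN1CCN(c2ccc(Nc3nc(-c4cccc(NC(=O)c5ccc(C(C)(C)C)cc5)c4)sc3C(N)=O)cc2)CC1` is the primary carboxamide bearing a tert-butyl group; in this assay compound 3 gives "not determined" (no result reported), so no number was reported for it either, and compound 3 stands without a value, its position relative to compound 2 not readable from the data. Compound 4 `CN1CCN(c2ccc(Nc3nc(-c4cccc(NC(=O)c5ccc(Cl)cc5)c4)sc3C(N)=O)cc2)CC1` differs from compound 3 only in the change (chloro in place of tert-butyl on an aromatic carbon), chloro in place of tert-butyl on an aromatic carbon. For the measured compounds named here, no step between measured compounds is available, so the size of this change in this assay cannot be gauged from the data, and the chance that the difference stays within the usual scatter is real. Taking the single measured value of compound 2 as the only anchor, compound 4 is expected to give 2000 nM, within an estimated range from 300 nM to 10000 nM.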

Compound 4, half-maximal inhibitory concentration: 5700 nM
The estimate for compound 4 lay 2.9-fold (0.45 log units) below the measured number; measured number inside the range.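

In this assay, amino in place of hydroxy on the carbonyl carbon gives a 1.2-fold lower number from compound 2 to compound 4 (0.09 log units; within the scatter), the first comparison available in this series. With the 4-chlorophenyl group held constant, the free acid and the primary carboxamide are therefore not told apart in this assay, so this exchange at the carbonyl carbon has no effect that can be distinguished from the usual scatter. Nothing available offers an explanation for this result.

The steps to compounds without a reported result cannot be read, so the change from tert-butyl to chloro remains unsized. Also open, as far as these compounds go, is how a methylamide or a nitrile in place of the primary carboxamide, or a methoxy or trifluoromethyl group in place of the chloro, would read in this assay.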